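Side-chain exchange on a shared core: compound 2 to compound 3

The source may hold more compounds than are shown below. What is called first, only, known or untested is meant among the compounds shown, and "the series" means these compounds.

Compound 2 `C[C@@H](O)[C@H](NC(=O)CN(c1nc(Cl)nc2[nH]cnc12)C1CC1)C(=O)O` and compound 1 `N=C(N)NCCC[C@H](NC(=O)CN(c1nc(Cl)nc2[nH]cnc12)C1CC1)C(=O)OCc1ccccc1` share a core and differ elsewhere. In a functional assay on the whole organism (Tail, strain ICR) with Mus musculus as the target, in the tail flick test, with a stated time of 30 min, at a dose of 25 umol/kg by the oral route (a lower number here means a weaker effect, a higher number a stronger effect of the compound at the dose given), compound 2 gives 18.6%, and compound 1 gives 23.2% in the same test, a gap within the usual scatter, so the two numbers give no order. Compound 3 `NC(=O)CC[C@H](NC(=O)CN(c1nc(Cl)nc2[nH]cnc12)C1CC1)C(=O)O` is not yet measured. It differs from compound 2 by 2-carbamoylethyl in place of 1-hydroxyethyl on a saturated chain carbon bound to an amide-type nitrogen and a carbonyl carbon. Going by the values given here, no step between measured compounds is available, so this change has no anchor; in this assay a step from compound 2 to compound 3 of no more than the scatter is expected, in either direction. Compound 3 is estimated at 21%, range 8% to 34%. The implied step a number 2.4 percentage points higher from compound 2 to compound 3 (within the scatter) is expected to stay within the scatter.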

Compound 3, a percentage reported as activity, at one dose (the size of the read-out at that dose, not a potency): 33.1%
Estimate against measurement, compound 3: 12.1 percentage points below, within the range that was stated.
By their numbers in this assay, from the lowest: compounds 2, 1 and 3 (each within the scatter of the next, the first and the last beyond it).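

In this assay, the saturated chain carbon bound to an amide-type nitrogen and a carbonyl carbon proves sensitive to side-chain exchange: 2-carbamoylethyl in place of 1-hydroxyethyl gives a number 14.5 percentage points higher from compound 2 to compound 3 (beyond the scatter). The earlier compounds shown here offered no readable step at this position. No measurement available here bears on the reason for this step.

As far as these compounds go, whether the step follows the carbamoyl group or the longer chain remains open. Carbamoylmethyl and 2-carboxyethyl on the same carbon would separate these two readings.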